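The source may hold more compounds than are shown below. What is called first, only, known or untested is meant among the compounds shown, and "the series" means these compounds.

Compounds measured in an assay on T47D cells for inhibition of Steryl-sulfatase (Homo sapiens), read by HPLC, with a stated time of 24 h; a lower number here means a stronger inhibitor, a higher number a weaker inhibitor:
compound 1, `Cc1ccccc1N(C)C(=O)c1ccc(-c2ccc(OS(N)(=O)=O)cc2)o1`, 28 nM
compound 2, `Cc1ccncc1N(C)C(=O)c1ccc(-c2ccc(OS(N)(=O)=O)cc2)o1`, 820 nM

Within the data shown here, compound 2 gives the higher of the two numbers in this assay, and its only neighbour is compound 1. Among the measured compounds shown here, the step between them, a 29-fold higher number from compound 1 to compound 2 (1.47 log units; beyond the scatter), is the single measured change that bears on the present comparison. Compound 3, `Cc1ncccc1N(C)C(=O)c1ccc(-c2ccc(OS(N)(=O)=O)cc2)o1`, differs from compound 2 in one place: 2-methylpyridin-3-yl in place of 4-methylpyridin-3-yl on an amide-type nitrogen. Both compounds keep the pyridine ring that distinguishes compound 2 from compound 1, so the large loss seen in that measured step is not expected to be reversed or repeated here; the methyl simply sits on a different position of the same ring, and nothing measured tells how much that matters. Compound 3 is therefore expected to stay near compound 2, with a step of a 1.2-fold lower number from compound 2 to compound 3 (0.07 log units; within the scatter) that is not expected to exceed the scatter. The estimate for compound 3 is 700 nM, within 200 nM to 2500 nM.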

Compound 3, half-maximal inhibitory concentration: 270 nM
Beside the measured number, compound 3's estimate is 2.6-fold (0.41 log units) above it, within the range that was stated.
By their numbers in this assay, from the lowest: compound 1; then compound 3; then compound 2.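

In this assay, the step of a 3.0-fold lower number from compound 2 to compound 3 (0.48 log units; beyond the scatter) shows that the place of the methyl on the pyridine ring matters, even though 2-methylpyridin-3-yl and 4-methylpyridin-3-yl have the same atoms and counts. The step of a 9.6-fold higher number from compound 1 to compound 3 (0.98 log units; beyond the scatter) shows that the cost of 2-methylphenyl giving way to a methylpyridinyl group depends on which isomer enters, although neither pyridine isomer reaches the number of compound 1. Nothing at hand gives a reason for either step.

From the compounds shown here alone, it remains open whether the methyl is needed at all on the pyridine ring, or whether a methoxy group or a chlorine atom in its place would give a lower number. How the other pyridine nitrogen placements would compare with 2-methylpyridin-3-yl also remains unsettled.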